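A few compounds are considered here, and "the series" means these few. Any claim that something is new, unique, unknown or untested is made for them only; others in the source may bear on it.

Series notes. The shared core of compound 2 is `Nc1scc(CN2CCN(c3ccncc3)CC2)c1C(=O)c1ccc(Cl)cc1`; compound 1 is `Nc1scc(CN2CCN(c3ccc([N+](=O)[O-])cc3)CC2)c1C(=O)c1ccc(Cl)cc1`. In a functional assay on CHO cells with adenosine receptor A1 (Homo sapiens) as the target, read by cAMP accumulation and immunoassay, with a stated time of 6 min, tested at 10 uM (on this read-out lower numbers stand for a stronger effect and higher numbers for a weaker effect at the one concentration tested), compound 1 gives -17% and compound 2 gives -15%; the two numbers sit within the scatter of each other, so the numbers shown give no order between them, and compound 2 is simply one of two equivalent values. Among the measured compounds shown here, the only measured step, a number 2 percentage points higher from compound 1 to compound 2 (within the scatter), is itself within the scatter.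

Compound 3 is `Nc1scc(CN2CCN(c3ccc(F)c(Cl)c3)CC2)c1C(=O)c1ccc(Cl)cc1`. Its difference from compound 2 is 3-chloro-4-fluorophenyl in place of pyridin-4-yl on an amine nitrogen in a ring. The step from compound 1 to compound 2 bears on this change, since it too swaps a six-membered aromatic group on the same ring nitrogen, and it moved nothing beyond the scatter. On that basis no step beyond the scatter in this assay is expected from compound 2 to compound 3; the expected step is no change at the digits printed from compound 2 to compound 3 (within the scatter).

Compound 3 is therefore estimated at -15% in this assay, with an expected range from -35% to 5%.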

Compound 3, a percentage reported as activity, at one concentration (the size of the read-out at that concentration, not a potency): -78%
For compound 3 the middle estimate is 63 percentage points above the measured one, and the stated range ends above it.
By their numbers in this assay, from the lowest: compound 3; then compounds 1 and 2 (each within the scatter of the next).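

In this assay, the group on the amine nitrogen in the ring is now shown to matter: the earlier swap of 4-nitrophenyl for pyridin-4-yl stayed within the scatter, whereas 3-chloro-4-fluorophenyl in this place brings a number 63 percentage points lower from compound 2 to compound 3 (beyond the scatter), and also a number 61 percentage points lower from compound 1 to compound 3 (beyond the scatter). Compound 3 therefore has the lowest number of the three and the strongest effect at the one concentration tested, while the other two groups remain indistinguishable, so a change of aromatic group here does not always leave the read-out unmoved. No data at hand bear on the origin of this step.

The compounds shown do not separate the contributions of the chlorine, the fluorine and the carbon-only aromatic ring, all of which enter together; an unsubstituted phenyl, or a phenyl carrying only the chlorine or only the fluorine, would divide them. Nor does a read-out at one concentration give a potency for compound 3, and whether the step holds with other groups on the shared core remains open.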